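Enlarging the Terminal Ring of a Basic Side Chain

The source may hold more compounds than are shown below. What is called first, only, known or untested is meant among the compounds shown, and "the series" means these compounds.

Of the compounds shown here, three built on one shared core have been tested in a functional assay on NCI-H460 cells (Homo sapiens) for cytotoxicity, read by MTT assay, with a stated time of 72 h; a lower number here means a stronger inhibitor, a higher number a weaker inhibitor. Compound 1 `COc1cc2c(Oc3ccc(NC(=O)c4cc(-c5ccc(F)cc5)ccn4)cc3F)ccnc2cc1OCCCN1CCCCC1` gives 250 nM. Compound 2 `COc1ccc(-c2ccnc(C(=O)Nc3ccc(Oc4ccnc5cc(OCCCN6CCCCC6)c(OC)cc45)c(F)c3)c2)cc1` gives 200 nM, and the change a 1.3-fold lower number from compound 1 to compound 2 (0.10 log units; within the scatter) stays within the scatter. Compound 3 `COc1cc2c(Oc3ccc(NC(=O)c4cc(-c5ccc(C)cc5)ccn4)cc3F)ccnc2cc1OCCCN1CCCC1` gives 160 nM; this is the lowest of the three numbers, but its gaps to compound 2 and to compound 1 are both within the scatter, so no ordering among the three can be claimed.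

Compound 4 `COc1cc2c(Oc3ccc(NC(=O)c4cc(-c5ccc(C)cc5)ccn4)cc3F)ccnc2cc1OCCCN1CCCCC1` has not yet been measured in this assay. It differs from compound 3 by piperidin-1-yl in place of pyrrolidin-1-yl on a saturated chain carbon, three bonds along the chain from an oxygen on an aromatic ring. Among the compounds with values here, none of the measured pairs differ in exactly this way, so no measured step speaks directly to the change. What can be said is that compound 1 and compound 2 already carry piperidin-1-yl at that same place, and their values sit close to that of compound 3, all within the scatter of one another.

On that basis the step from compound 3 to compound 4 is expected to be small, a 1.2-fold higher number from compound 3 to compound 4 (0.07 log units; within the scatter), with no clear direction. Compound 4 is therefore estimated at 190 nM, with a likely range from 90 nM to 400 nM.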

Compound 4, half-maximal inhibitory concentration: 160 nM
For compound 4 the middle estimate is 1.2-fold (0.07 log units) above the measured one; the measured number falls inside the stated range.
By their numbers in this assay, from the lowest: compounds 3, 4, 2 and 1 (each within the scatter of the next).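

In this assay, the swap of pyrrolidin-1-yl for piperidin-1-yl now has its first direct reading, with methyl held fixed on the aromatic carbon of the shared core: enlarging the ring on this saturated chain carbon, three bonds along the chain from an oxygen on an aromatic ring, gives no change at the digits printed from compound 3 to compound 4 (within the scatter). Compound 4 also completes a small series in which piperidin-1-yl stays fixed and only the group on the aromatic carbon changes, giving a 1.3-fold lower number from compound 2 to compound 4 (0.10 log units; within the scatter) and a 1.6-fold lower number from compound 1 to compound 4 (0.19 log units; within the scatter). Within the data shown here, no measurement is available that could explain these results, which show only that neither the ring swap nor the changes among fluoro, methoxy and methyl separate these compounds in this assay.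

On these data alone, the ring swap has been read only with methyl on the aromatic carbon, so its effect with fluoro or methoxy there remains open. Also open, as far as these compounds go, is whether morpholin-4-yl in place of piperidin-1-yl, or 2-(piperidin-1-yl)ethyl in place of 3-(piperidin-1-yl)propyl, would stay within the same narrow band of values.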